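Fluoro in place of methoxy on compound 3

This account rests on a few compounds, and the source may have more. Where it says the series, first, only, none or still open, it means among the compounds named here.

In a functional assay on PC-3 cells (Homo sapiens) for inhibition, read by MTT assay, with a stated time of 48 h (on this read-out lower numbers stand for stronger inhibition and higher numbers for weaker inhibition), compound 1 (`COc1ccc(-n2c(SC)nnc2-c2cc(OC)c(OC)c(OC)c2)cc1`) gives > 60000 nM, which is a limit and not a number. Among the compounds with values here, compound 2 (`COc1ccc(-n2c(SCc3ccc(F)cc3)nnc2-c2cc(OC)c(OC)c(OC)c2)cc1`) gives 35000 nM, the only true number so far. Compound 3 (`COc1ccc(C(=O)CSc2nnc(-c3cc(OC)c(OC)c(OC)c3)n2-c2ccc(OC)cc2)cc1`) gives > 60000 nM, again a limit and not a number. Compound 3 therefore stands at the limit of > 60000 nM in this assay, at which 2 of the 3 values shown sit.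

Compound 4 (`COc1ccc(-n2c(SCC(=O)c3ccc(F)cc3)nnc2-c2cc(OC)c(OC)c(OC)c2)cc1`) differs from compound 3 in one place: fluoro in place of methoxy on an aromatic carbon. This is fluoro in place of methoxy on an aromatic carbon, para to a large group, so that (4-methoxyphenyl)carbonyl becomes (4-fluorophenyl)carbonyl.

Within the data shown here, no measured step isolates this change. The nearest are an at least 1.7-fold higher number from compound 2 to compound 3 (0.23 log units; that floor lies within the scatter) and an at least 1.7-fold lower number from compound 1 to compound 2 (0.23 log units; that floor lies within the scatter), and each gives only a floor. The third, a step that the two limits leave unreadable from compound 1 to compound 3, cannot be read. Compound 2 does carry a 4-fluorophenyl, but on the chain carbon without the carbonyl, so it offers only a weak hint of a lower number.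

No step beyond the scatter is therefore expected in this assay, and another reading at the limit remains quite possible. The estimated step is an at least 1.2-fold lower number from compound 3 to compound 4 (0.07 log units; that floor lies within the scatter). Compound 4 is expected at 50000 nM, with an estimated range of 25000 nM to 100000 nM.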

Compound 4, half-maximal inhibitory concentration: 58300 nM
The estimate for compound 4 lay 1.2-fold (0.07 log units) below the measured number; low and high end bracket the measured number.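

In this assay, within the data shown here, compound 4 gives the (4-fluorophenyl)carbonyl member of the series a true number, which bounds fluoro in place of methoxy on an aromatic carbon, para to a large group, for the first time: an at least 1.0-fold lower number from compound 3 to compound 4 (0.01 log units; that floor lies within the scatter). That floor is close to no information on the size of the change, and compound 3 remains a limit and not a number: the limit of > 60000 nM in this assay, at which 2 of the 4 values shown sit. Compound 4 also gives the series its first pair of true numbers, with a 1.7-fold higher number from compound 2 to compound 4 (0.22 log units; within the scatter), and the remaining comparison gives only a floor, an at least 1.0-fold lower number from compound 1 to compound 4 (0.01 log units; that floor lies within the scatter), so swapping 4-fluorophenyl for (4-fluorophenyl)carbonyl on the chain carbon bound to the sulfur shows no step beyond the scatter.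

Among these compounds, still open is whether any group at this aromatic carbon can move the number beyond the scatter, given that every readable step so far stays within it or gives only a floor inside it. A chloro, a hydroxyl or an amine in place of the fluoro, or a longer chain on the sulfur, would show whether this read-out responds to either part of the molecule.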